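A few compounds are considered here, and "the series" means these few. Any claim that something is new, unique, unknown or untested is made for them only; others in the source may bear on it.

Compound 1 `CN1CCC(C(=O)N2Cc3c(NC(=O)c4ccsc4)n[nH]c3C2(C)C)CC1`: > 225000 nM
Compound 2 `CC(=O)N1CCN(C(=O)N2Cc3c(NC(=O)c4ccc(F)cc4)n[nH]c3C2(C)C)CC1`: > 225000 nM

Of the compounds shown here, two have been measured in a physicochemical assay for solubility, at pH 7; a lower number here means a less soluble compound, a higher number a more soluble compound. For compound 1 the value > 225000 nM is a limit of the assay and not a number. For compound 2 the value > 225000 nM is likewise a limit. Both sit at the limit of > 225000 nM in this assay, at which 2 of the 2 values shown sit. Compound 1 therefore stands at the top of what this assay can report, and compound 2 stands at the same place, so the two cannot be ordered against each other on these numbers.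

Compound 3 `CN1CCC(C(=O)N2Cc3c(NC(=O)c4ccncc4)n[nH]c3C2(C)C)CC1` has not yet been measured. It differs from compound 1 in one place: pyridin-4-yl in place of thiophen-3-yl on a carbonyl carbon. Among the compounds with values here, no step between two measured compounds is available, so the size of the change from compound 1 to compound 3 cannot be read from any measured pair. Given that compound 1 sits at the limit of > 225000 nM in this assay, at which 2 of the 2 values shown sit, the step that the limit leaves unreadable from compound 1 to compound 3 is expected to be none beyond the scatter, with the result most likely reported as a limit again. The solubility of compound 3 in this assay is estimated at 250000 nM, within a range from 90000 nM to 600000 nM.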

Compound 3, solubility: > 225000 nM
Compound 3 ended at the assay's limit; the forecaster's own chance of this, stated with the estimate: 75%; the middle value is on the limit's open side.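

In this assay compound 3 gives > 225000 nM, which is a limit and not a number. No step can be read from compound 1 to compound 3, since both values are limits: (the limit of > 225000 nM in this assay, at which 3 of the 3 values shown sit). The compounds shown leave open how compound 1, compound 2 and compound 3 rank against one another, and what change to the shared core would give a value below the limit.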